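The source may hold more compounds than are shown below. What is called first, only, known or untested is meant among the compounds shown, and "the series" means these compounds.

Measured so far in an assay on membranes from liver for displacement of a labelled ligand from Sigma non-opioid intracellular receptor 1 (Rattus norvegicus), read by radiometric assay, with a stated time of 60 min, in the presence of a further agent that is not named here; a lower number here means a stronger inhibitor, a higher number a weaker inhibitor:
Compound 1, `O=C(c1ccc(F)cc1)C1CCN(Cc2ccc(Br)cc2)CC1`, gives 1.4 nM in this assay.
Compound 2, `OC(c1ccc(F)cc1)C1CCN(Cc2ccc(F)cc2)CC1`, gives 1.41 nM in this assay.

Compound 2 holds the higher of the two numbers, yet its nearest neighbour, compound 1, stands within the scatter of it, so no order can be read between the two. Compound 3, `Cc1ccc(CN2CCC(C(O)c3ccc(F)cc3)CC2)cc1`, has not been measured. Against compound 2 it shows (methyl in place of fluoro on an aromatic carbon), methyl in place of fluoro on an aromatic carbon. Among the measured compounds shown here, no measured pair covers this change on its own; compounds 1 and 2 differ in more than one place and their values sit together, which is the only hint that the group on that ring may be exchanged without much cost. The expectation is a step within the scatter, with at most a slight drift to a lower number. Compound 3 is estimated at 1.2 nM, within 0.5 nM to 3 nM, an expected step of a 1.2-fold lower number from compound 2 to compound 3 (0.07 log units; within the scatter).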

Compound 3, inhibition constant: 1.45 nM
Compound 3: the middle estimate sits 1.2-fold (0.08 log units) below what was measured; the measured number falls inside the stated range.
By their numbers in this assay, from the lowest: compounds 1, 2 and 3 (each within the scatter of the next).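

In this assay, among the compounds shown here, the change from 4-fluorophenyl to 4-methylphenyl, para to a large group, gives a 1.0-fold higher number from compound 2 to compound 3 (0.01 log units; within the scatter) and is the first comparison that isolates this position. The earlier hint that the group on this ring can be exchanged at little cost now rests on a direct single-place pair, but only for fluoro and methyl with the hydroxy-bearing carbon held constant. No supporting data bear on why the exchange leaves the number within the scatter.

Going by these compounds, it remains open whether this position would accept an amine, a carboxylic acid or a longer chain as readily. On these data alone, the separate contribution of the carbonyl in compound 1 and the hydroxy-bearing carbon in compound 2 also remains open, as those two compounds differ in more than one place.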